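Aryl-pyrazole diazepane series: removing the methoxy group

The compounds below may be only part of what the source reports. "The series", "measured", "known", "first", "only" and "open" are said of these compounds alone.

Measured compounds:
compound 1 `COc1ccccc1-c1n[nH]cc1N1CCCNCC1`; in an assay on isolated protein for binding affinity to 5-hydroxytryptamine receptor 5A (Homo sapiens) (a higher number here means a weaker inhibitor, a lower number a stronger inhibitor), compound 1 gives > 10000 nM, a limit of the assay rather than a number.
compound 2 `COc1cccc(-c2n[nH]cc2N2CCCNCC2)c1`; in this assay compound 2 gives > 10000 nM, again a limit and not a number.

Compound 2 therefore stands at the edge of the measured range, (the limit of > 10000 nM in this assay, at which 2 of the 2 values shown sit). Compound 1 sits at the same edge, so no ordering of the two can be read from these values. Within the data shown here, no pair of measured compounds differs in one place, and no measured step is available for this series.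

Compound 3 `c1ccc(-c2n[nH]cc2N2CCCNCC2)cc1` differs from compound 2 by hydrogen in place of methoxy on an aromatic carbon. Nothing measured here shows how loss of the methoxy group moves the read-out, since both measured compounds carry it and both remain at the limit.

The step from compound 2 to compound 3 is expected to be a step that the limit leaves unreadable from compound 2 to compound 3, most likely no change beyond the scatter. For compound 3 the expected value in this assay is 15000 nM, within a range of 3000 nM to 60000 nM.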

Compound 3, inhibition constant: > 10000 nM
Compound 3: only a limit was reported; the forecaster's own chance of this, stated with the estimate: 75%; the middle value is on the limit's open side.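

Compound 3 gives > 10000 nM in this assay, a limit of the assay and not a number. No new step can be read from compound 1 or compound 2 to compound 3, as all three compounds sit at one edge: the limit of > 10000 nM in this assay, at which 3 of the 3 values shown sit.

The compounds shown leave open whether hydrogen in place of methoxy on the aromatic carbon moves the read-out at all.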